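Trading an acetyl for hydrogen on a shared core

This account rests on a few compounds, and the source may have more. Where it says the series, first, only, none or still open, it means among the compounds named here.

Compound 1, `C=C1C(=O)O[C@]2(C)CC[C@@H]1C[C@H](O)[C@@]1(C)CC[C@H](OC(C)=O)[C@@](C)(CCC2=O)O1`: in a functional assay on MCF7 cells (Homo sapiens) for cytotoxicity, read by MTT assay (on this read-out higher numbers stand for an effect only at larger amounts of compound and lower numbers for an effect already at smaller amounts), compound 1 gives < 20 ug/mL, which is a limit of the assay rather than a number.
Compound 2, `C=C1C(=O)O[C@]2(C)CC[C@@H]1C[C@H](O)[C@@]1(C)CC[C@H](O1)[C@](C)(O)CC[C@H]2OC(C)=O`: in this assay compound 2 gives < 20 ug/mL, again a limit of the assay.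
Compound 3, `C=C1C(=O)O[C@]2(C)CC[C@@H]1C[C@H](OC(C)=O)[C@@]1(C)CC[C@H](O1)[C@](C)(O)CC[C@H]2OC(C)=O`: in this assay compound 3 gives < 20 ug/mL, also a limit of the assay.

Compound 2 therefore stands at the same limit as every other measured compound, since all values sit at the limit of < 20 ug/mL in this assay, at which 3 of the 3 values shown sit. Among the compounds with values here, the one measured change of an acetyl against hydrogen on an oxygen on a saturated carbon, a step that the two limits leave unreadable from compound 2 to compound 3, cannot be read, because both ends are limits.

The unmeasured compound 4, `C=C1C(=O)O[C@]2(C)CC[C@@H]1C[C@H](O)[C@@]1(C)CC[C@H](O1)[C@](C)(O)CC[C@H]2O`, differs from compound 2 by hydrogen in place of acetyl on an oxygen on a saturated carbon. Within the data shown here, no measured step gives a size for such a change, so no direction can be drawn from the data. Compound 4 is expected to give about 10 ug/mL in this assay, within 2 ug/mL to 40 ug/mL. The step that the limit leaves unreadable from compound 2 to compound 4 is thus estimated to stay within the scatter, most likely as another limit.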

Compound 4, concentration for half-maximal effect: < 20 ug/mL
Compound 4 was reported as a limit (the forecaster's own chance of this, stated with the estimate: 65%); the middle value lies beyond the limit too.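

No step can be read from compound 2 to compound 4, because both values are limits of the assay, as are those of the other compounds: the limit of < 20 ug/mL in this assay, at which 4 of the 4 values shown sit.

The compounds shown leave open how large an effect the change from acetoxy to hydroxy has in this assay, and whether these compounds differ from one another at all.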